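The source may hold more compounds than are shown below. What is called first, only, known or untested is meant among the compounds shown, and "the series" means these compounds.

Measured so far:
compound 1 `CNC(=O)c1cc(Oc2ccc3nc(NC(=O)Nc4cc(C(F)(F)F)cc(C(F)(F)F)c4)sc3c2)ccn1` — 98.4%
compound 2 `CNC(=O)c1cc(Oc2ccc3nc(NC(=O)c4cccc(F)n4)sc3c2)ccn1` — 55.5%
compound 3 `CNC(=O)c1cc(Oc2ccc3nc(NC(=O)c4cc(C(F)(F)F)cc(C(F)(F)F)c4)sc3c2)ccn1` — 76.9%

In a functional assay on HCT-116 cells (Homo sapiens) for inhibition, read by MTT assay, with a stated time of 2 days, tested at 100 uM (a higher number here means more inhibition of growth at the concentration tested, a lower number less inhibition of growth), compound 2 gives the lowest of the three numbers; compound 3 lies beyond the scatter above it, and compound 1 further still. Compound 4 `CNC(=O)c1cc(Oc2ccc3nc(NC(=O)Nc4ccc(F)cc4)sc3c2)ccn1` is not yet measured. It differs from compound 2 in one place: (4-fluorophenyl)amino in place of 6-fluoropyridin-2-yl on a carbonyl carbon. Going by the values given here, no pair measured here differs in exactly this way, so the step has no direct precedent. The nearest hint is that compound 1, with 98.4%, stands well above compound 3, with 76.9%, the two sharing the same outer aryl group and differing at the carbonyl carbon in the same way. On that basis an upward step beyond the scatter is expected from compound 2 to compound 4, estimated at a number 20.5 percentage points higher from compound 2 to compound 4 (beyond the scatter). Compound 4 is expected to give about 76%, within 55% to 95%.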

Compound 4, percent growth inhibition at one concentration: 83.8%
The estimate for compound 4 lay 7.8 percentage points below the measured number, within the range that was stated.
By their numbers in this assay, from the lowest: compound 2; then compounds 3 and 4 (each within the scatter of the next); then compound 1.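

In this assay, going by these compounds alone, (4-fluorophenyl)amino in place of 6-fluoropyridin-2-yl on a carbonyl carbon gives the first direct reading at this position, a number 28.3 percentage points higher from compound 2 to compound 4 (beyond the scatter). The change replaces a ring with one hetero atom by a ring of carbon only and also adds an amino nitrogen, so this single step cannot assign the gain to either part. No measurement on hand explains the step.

Open, going by these compounds, is whether the amino nitrogen alone, with the 6-fluoropyridin-2-yl ring kept, gives a similar step. Also open, on these data alone, is how a saturated amine such as morpholine would read on the same carbonyl carbon.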